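Cyclohexyl in place of isopropoxy in compound 3

The compounds below may be only part of what the source reports. "The series", "measured", "known", "first", "only" and "open" are said of these compounds alone.

Measured in a functional assay on brain (Rattus norvegicus, strain Wistar) for inhibition; on this read-out lower numbers stand for stronger inhibition and higher numbers for weaker inhibition:
- compound 1 `CCCCc1ccc(-c2c(C)[nH]c(=O)n2CCCC)cc1`: 12000 nM
- compound 2 `CCCCc1ccc(-c2c(C)[nH]c(=O)n2C2CCCCC2)cc1`: 27100 nM
- compound 3 `Cc1[nH]c(=O)n(C)c1-c1ccc(OC(C)C)cc1`: 20400 nM

Compound 3 lies within the usual scatter of both compound 1 and compound 2, so the three values give it no rank of its own in this assay. Compound 4 `Cc1[nH]c(=O)n(C)c1-c1ccc(C2CCCCC2)cc1` has not yet been measured. It differs from compound 3 by cyclohexyl in place of isopropoxy on an aromatic carbon.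

Going by the values given here, only one measured step brings in a cyclohexyl group: a 2.3-fold higher number from compound 1 to compound 2 (0.35 log units; beyond the scatter). That modest step replaced butyl on an aromatic nitrogen, not a group on an aromatic carbon, so it offers a rough guide to size but none to direction. Among the compounds with values here, no measured pair tests the change at this position. A small step is therefore expected, probably not beyond the scatter. The expected step is a 1.4-fold lower number from compound 3 to compound 4 (0.13 log units; within the scatter). For compound 4 the estimated value is 15000 nM, with an expected range from 6000 nM to 40000 nM.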

Compound 4, half-maximal inhibitory concentration: 10000 nM
Compound 4: middle estimate off by 1.5-fold (0.18 log units), on the high side; the measured number falls inside the stated range.
By their numbers in this assay, from the lowest: compounds 4, 1, 3 and 2 (each within the scatter of the next, the first and the last beyond it).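

In this assay, the aromatic carbon that carries isopropoxy in compound 3 also accepts cyclohexyl, a ring of carbon only without the hydrogen-bond acceptor of the group it replaces, and the change gives a 2.0-fold lower number from compound 3 to compound 4 (0.31 log units; beyond the scatter). Going by these compounds alone, the only earlier cyclohexyl step, on an aromatic nitrogen, gave a 2.3-fold higher number from compound 1 to compound 2 (0.35 log units; beyond the scatter), so the same group moves the number in opposite directions at these two places, though each step is modest and the two were read in different compounds. Nothing measured here accounts for the new step.

On these data alone, whether the step follows the loss of the oxygen or the arrival of the ring stays open, and a cyclohexyloxy group on this carbon would separate the two. As far as these compounds go, how an amine or a carboxylic acid at this place would read in this assay also remains open.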